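The compounds below may be only part of what the source reports. "The series", "measured", "known", "first", "only" and "open" are said of these compounds alone.

Measured compounds:
compound 1 `CC(C)(C)OC(=O)NCCNC(=O)CN1CN(c2ccccc2)C2(CCN(C(=O)c3ccc(C(C)(C)C)cc3)CC2)C1=O` — 10900 nM
compound 2 `CC(C)(C)OC(=O)NC1CCN(C(=O)CN2CN(c3ccccc3)C3(CCN(C(=O)c4ccc(C5CCCCC5)cc4)CC3)C2=O)CC1` — 4800 nM

Both values come from an assay on HEK293 cells for displacement of a labelled ligand from NPC1-like intracellular cholesterol transporter 1 (Homo sapiens); a lower number here means a stronger inhibitor, a higher number a weaker inhibitor. In this assay compound 1 gives 10900 nM, the highest of the two numbers. Compound 2 gives 4800 nM, a lower number, and the gap between the two lies beyond the usual scatter. Among the compounds with values here, no single-point step between measured compounds is available, so the series offers no direct calibration for changes at the carbonyl carbon.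

Compound 3 `CC(C)(C)c1ccc(C(=O)N2CCC3(CC2)C(=O)N(CC(=O)N2CCCC(O)C2)CN3c2ccccc2)cc1` is not yet measured. It differs from compound 1 as follows: 3-hydroxypiperidin-1-yl in place of (2-((tert-butoxycarbonyl)amino)ethyl)amino on a carbonyl carbon. Both carry the same core, differing only in the group on that carbonyl carbon.

Within the data shown here, with no comparable step on record, the expectation for compound 3 is a number close to that of compound 1, with a step of a 1.4-fold lower number from compound 1 to compound 3 (0.13 log units; within the scatter) that may not exceed the scatter. Compound 3 is estimated at 8000 nM, with a range from 2500 nM to 25000 nM.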

Compound 3, half-maximal inhibitory concentration: 12200 nM
Compound 3: middle estimate off by 1.5-fold (0.18 log units), on the low side; the range from low to high includes it.
By their numbers in this assay, from the lowest: compound 2; then compounds 1 and 3 (each within the scatter of the next).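

Within the data shown here, with 3-hydroxypiperidin-1-yl in place of (2-((tert-butoxycarbonyl)amino)ethyl)amino on a carbonyl carbon, this assay gives a 1.1-fold higher number from compound 1 to compound 3 (0.05 log units; within the scatter), the first direct reading for this position. On this one pair, an open chain without a ring and a six-membered non-aromatic ring with fewer heavy atoms cannot be told apart, so the tert-butoxycarbonyl group is not needed to retain a number of this size on the core of compound 1. No supporting measurement accompanies this pair, and the result remains a description only.

Still open, on these data alone, is whether the hydroxyl group matters, which plain piperidin-1-yl on the same carbonyl carbon would test, and whether a primary amine or a carboxylic acid there would move the number beyond the scatter. Compound 2 differs from compound 1 in more than one place, so its number cannot be tied to this position.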